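The source may report more compounds than this note shows. Statements on the series, on what has been measured and on what is new or still open speak of the compounds shown alone.

Measured so far in an assay on cells for displacement of a labelled ligand from neurotensin receptor type 2 (Homo sapiens), with a stated time of 30 min; a lower number here means a stronger inhibitor, a higher number a weaker inhibitor:
compound 1 `CC[C@H](C)[C@H](NC(=O)[C@H](CCCCN)NC(=O)[C@@H]1CCCN1C(=O)[C@H](CCCCN)NC(=O)[C@@H](N)CCCCN)C(=O)N[C@@H](CC(C)C)C(=O)O`, 262 nM
compound 2 `CC[C@H](C)[C@H](NC(=O)C(CCCN)NC(=O)[C@@H]1CCCN1C(=O)[C@H](CCCCN)NC(=O)[C@@H](N)CCCCN)C(=O)N[C@@H](CC(C)C)C(=O)O`, 620 nM

Compound 1 holds the lowest of the two numbers; compound 2 sits higher, and that gap lies beyond the usual scatter. Compound 3 `CC[C@H](C)[C@H](NC(=O)[C@H](CCCCN)NC(=O)[C@@H]1CCCN1C(=O)[C@H](CCCCN)NC(=O)[C@@H](N)CCCCN)C(=O)N[C@H](C[Si](C)(C)C)C(=O)O` has not yet been measured in this assay. It differs from compound 1 by a group of 9 heavy atoms (6 carbon, 2 oxygen, 1 silicon; no ring) in place of a group of 8 heavy atoms (6 carbon, 2 oxygen; no ring), on an amide-type nitrogen. Among the compounds with values here, no measured step of this kind exists, so the change is expected to move the number only a little, if at all, and more likely slightly upward than downward. Compound 3 is estimated at 320 nM, with a range from 120 nM to 900 nM, corresponding to an expected step of a 1.2-fold higher number from compound 1 to compound 3 (0.09 log units; within the scatter).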

Compound 3, inhibition constant: 67 nM
Compound 3: middle estimate off by 4.8-fold (0.68 log units), on the high side; the whole stated range lies above it.
By their numbers in this assay, from the lowest: compound 3; then compound 1; then compound 2.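

On an amide-type nitrogen in this assay, replacing 1-carboxy-3-methylbutyl with the silicon-bearing group gives a 3.9-fold lower number from compound 1 to compound 3 (0.59 log units; beyond the scatter), so this position tolerates the larger group and responds to the change. As drawn, the two structures also have opposite spatial arrangements at the defined stereocentre of this group, so the step cannot be assigned to silicon alone. No measurement shown explains the step.

Open, as far as these compounds go, is how the same group with carbon in place of silicon would compare at either stereocentre arrangement. Also open, from the compounds shown here alone, is how a primary amide in place of the carboxylic acid would read.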